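The source may report more compounds than this note shows. Statements on the series, on what has been measured and on what is new or still open speak of the compounds shown alone.

Among the measured compounds shown here, in a functional assay on SU-DHL-6 cells (Homo sapiens) for antiproliferative activity, read by MTT assay (on this read-out higher numbers stand for weaker inhibition and lower numbers for stronger inhibition), compound 1 `COc1ncc(-c2ccc3ncnc(N[C@H]4CCCN(C(=O)C5CCN(C)CC5)C4)c3c2)cc1C#N` gives 420 nM and holds the lower of the two numbers measured so far. In this assay compound 2 `COc1ncc(-c2ccc3ncnc(N[C@H]4CCCN(C(=O)C(F)(F)F)C4)c3c2)cc1[N+](=O)[O-]` gives 127000 nM as a far higher number, and that gap lies well beyond the usual scatter of repeat measurements. Two values do not make a trend, and these two compounds do not differ in just one place.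

Compound 3 `COc1ncc(-c2ccc3ncnc(N[C@H]4CCCN(C(=O)C(C)N)C4)c3c2)cc1C#N` keeps the core of compound 1 and carries 1-aminoethyl in place of 1-methylpiperidin-4-yl on a carbonyl carbon, a difference counted as 1-aminoethyl in place of 1-methylpiperidin-4-yl on a carbonyl carbon and the only one between them. For the measured compounds named here, no measured pair shows what a change at this place does, so the expectation is cautious. Starting from compound 1 at 420 nM a modest move toward weaker inhibition is expected in this assay rather than a collapse. The expected size of this move is a 2.1-fold higher number from compound 1 to compound 3 (0.33 log units; beyond the scatter) and it is a rough estimate. In this assay the estimated value for compound 3 is 900 nM and the expected range runs from 250 nM to 3500 nM.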

Compound 3, half-maximal inhibitory concentration: 440 nM
Beside the measured number, compound 3's estimate is 2.0-fold (0.31 log units) above it; measured number inside the range.
By their numbers in this assay, from the lowest: compounds 1 and 3 (each within the scatter of the next); then compound 2.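

In this assay, putting 1-aminoethyl in place of 1-methylpiperidin-4-yl on a carbonyl carbon gives a 1.0-fold higher number from compound 1 to compound 3 (0.02 log units; within the scatter) and so the two compounds cannot be told apart on this read-out. This is the first pair shown that differs in one place only, and it reveals that at this place the six-membered non-aromatic ring can be exchanged for a group with no ring, going from 7 heavy atoms to 3 and gaining a hydrogen-bond donor, without a difference beyond the scatter. No measurement at hand explains why these two groups give matching numbers.

This single pair cannot show how much freedom the position allows in general, since other groups on the same carbonyl carbon, such as a longer chain ending in an amine or one ending in a carboxylic acid, are not among the compounds shown. Compound 2 differs from compound 1 in more than one place, so the compounds shown also leave open how much of its far higher number belongs to the group on the carbonyl carbon.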